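Swapping the ketone aryl group in a chalcone-type pyrazole series

A few compounds are considered here, and "the series" means these few. Any claim that something is new, unique, unknown or untested is made for them only; others in the source may bear on it.

Of the compounds shown here, two of a shared core have been tested in a functional assay on MCF7 cells (Homo sapiens) for inhibition, read by sulforhodamine B assay, with a stated time of 72 h; a higher number here means a weaker inhibitor, a lower number a stronger inhibitor. Compound 1, `COc1ccc(C(=O)/C=C/c2cn(-c3ccccc3)nc2-c2ccsc2)cc1OC`, gives 2800 nM. Compound 2, `O=C(/C=C/c1cn(-c2ccccc2)nc1-c1cccnc1)c1ccccn1`, gives 4200 nM. These two numbers lie within the usual scatter of each other, so compound 2 stands alongside compound 1 rather than apart from it, and nothing can be said about which of the two is the stronger inhibitor.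

Compound 3, `O=C(/C=C/c1cn(-c2ccccc2)nc1-c1cccnc1)c1c[nH]c2ccccc12`, has not yet been measured in this assay . It differs from compound 2 in one place: 1H-indol-3-yl in place of pyridin-2-yl on a carbonyl carbon. The rest of the molecule, the core with its phenyl and pyridin-3-yl groups and the double-bonded chain, is unchanged.

Among the measured compounds shown here, no measured pair shows what this kind of exchange does on this core, so the expectation rests on the two numbers alone, which sit close together. The step from compound 2 to compound 3 is estimated to be a 1.4-fold lower number from compound 2 to compound 3 (0.15 log units; within the scatter), with no clear direction beyond the scatter. Compound 3 is therefore expected to give about 3000 nM in this assay , with a range from 1000 nM to 10000 nM.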

Compound 3, half-maximal inhibitory concentration: 2600 nM
Compound 3: middle estimate off by 1.2-fold (0.06 log units), on the high side; the range from low to high includes it.
By their numbers in this assay, from the lowest: compounds 3, 1 and 2 (each within the scatter of the next).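

In this assay, the position on the carbonyl carbon gives its first readable step: 1H-indol-3-yl in place of pyridin-2-yl gives a 1.6-fold lower number from compound 2 to compound 3 (0.21 log units; within the scatter). This exchange is a substantial one on paper, since the entering group carries a five-membered and a six-membered aromatic ring and a hydrogen-bond donor, while the group that leaves has one six-membered aromatic ring and a hydrogen-bond acceptor, yet the two compounds cannot be told apart in this assay. No measurement at hand bears on what lies behind this result.

A single step at one position cannot show whether other groups on this carbonyl carbon would also stay within the scatter, for example a small alkyl chain such as butyl, an amine or a carboxylic acid. It also leaves open whether the hydrogen on the indole nitrogen matters, which a comparison with 1-methyl-1H-indol-3-yl at the same place could test while the rest of the molecule stays unchanged.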